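Methyl on the Ring Nitrogen: From Compound 2 to Compound 3

A few compounds are considered here, and "the series" means these few. Any claim that something is new, unique, unknown or untested is made for them only; others in the source may bear on it.

Compound 1, `Cn1c(-c2ccccc2)cc(=O)[nH]c1=O`, in a functional assay on the whole organism for inhibition, with Rattus norvegicus as the target, at a dose of 100 mg/kg by the oral route; a lower number here means a weaker effect, a higher number a stronger effect of the compound at the dose given: 79%
Compound 2, `Cn1c(-c2ccccc2)c(Br)c(=O)[nH]c1=O`, in this assay: 57%

Compound 2 holds the lower of the two numbers: the change of a number 22 percentage points lower from compound 1 to compound 2 (beyond the scatter) sets it apart from compound 1. Compound 3, `Cn1c(-c2ccccc2)c(Br)c(=O)n(C)c1=O`, differs from compound 2 by methyl in place of hydrogen on an aromatic nitrogen. Among the measured compounds shown here, no measured step touches this change; the one step known, a number 22 percentage points lower from compound 1 to compound 2 (beyond the scatter), concerns bromo in place of hydrogen and says nothing about a methyl on nitrogen. A step in this assay of no size beyond the scatter is therefore expected. Compound 3 is estimated at 50%, between 25% and 75%, which means an expected a number 7 percentage points lower from compound 2 to compound 3 (within the scatter).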

Compound 3, a percentage reported as inhibition, in the whole organism at one dose (the size of the read-out at that dose, not a potency): 59%
The estimate for compound 3 lay 9 percentage points below the measured number, within the range that was stated.
By their numbers in this assay, from the lowest: compounds 2 and 3 (each within the scatter of the next); then compound 1.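

In this assay, among the compounds shown here, the first change at this aromatic nitrogen, methyl in place of hydrogen, stays within the scatter (a number 2 percentage points higher from compound 2 to compound 3 (within the scatter)). Compounds 1 and 2 both carry hydrogen there, so only compound 3 shows that, with the bromo group present, this methyl leaves the read-out at one dose unchanged within the scatter. No measurement at hand accounts for this result.

The compounds shown leave open whether a longer chain or a carboxylic acid on this nitrogen would do the same. They also leave open whether this methyl would behave alike in compound 1, which has hydrogen instead of bromo.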